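Replacing the Sulfonamide Arm on the Piperidine of Compound 1

A few compounds are considered here, and "the series" means these few. Any claim that something is new, unique, unknown or untested is made for them only; others in the source may bear on it.

Measured compounds:
compound 1, `O=S(=O)(NCC1CCN(CCCc2c[nH]c3ccc(-n4cnnc4)cc23)CC1)c1ccccc1`, 12 nM
compound 2, `COC[C@H](NC1CCN(CCCc2c[nH]c3ccc(Cn4cncn4)cc23)CC1)c1ccc(F)cc1`, 8.9 nM
compound 3, `OC[C@H](NC1CCN(CCCc2c[nH]c3ccc(-n4ccnc4)cc23)CC1)c1ccccc1`, 0.8 nM

In an assay on CHO cells for agonist activity at 5-hydroxytryptamine receptor 1D (Homo sapiens), read by GTPgammaS binding (a higher number here means that more compound is needed for the effect, a lower number that less compound is needed), compound 1 gives the highest of the three numbers. Compound 2 sits within the scatter of it, so no order can be read between them, while compound 3 lies well beyond the scatter with a much lower number. Compound 4, `CN(Cc1ccsc1)C1CCN(CCCc2c[nH]c3ccc(-n4cnnc4)cc23)CC1`, has not yet been measured. It differs from compound 1 in one place: methyl((thiophen-3-yl)methyl)amino in place of ((phenylsulfonyl)amino)methyl on a saturated ring carbon. Compounds 2 and 3 carry an amino group directly on the same saturated ring carbon, and both give lower numbers than compound 1, though neither step has been computed. Compound 4 is therefore expected to show a modest move toward a lower number in this assay, near the edge of the scatter, a step of a 2.4-fold lower number from compound 1 to compound 4 (0.38 log units; beyond the scatter). The estimate for compound 4 is 5 nM, within 1.5 nM to 20 nM.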

Compound 4, half-maximal effective concentration: 4.2 nM
Estimate against measurement, compound 4: 1.2-fold (0.08 log units) above, within the range that was stated.
By their numbers in this assay, from the lowest: compound 3; then compound 4; then compounds 2 and 1 (each within the scatter of the next).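

In this assay, among these compounds, the one change on the saturated ring carbon, methyl((thiophen-3-yl)methyl)amino in place of ((phenylsulfonyl)amino)methyl, gives a 2.9-fold lower number from compound 1 to compound 4 (0.46 log units; beyond the scatter) on an otherwise unchanged structure. The ((phenylsulfonyl)amino)methyl group, with its hydrogen-bond donor and six-membered aromatic ring, is therefore not needed at this position for a number this low. Nothing available explains the step.

From the compounds shown here alone, whether a secondary amine without the methyl would do the same remains open. So does the effect of a phenyl or furan ring in place of the thiophene.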